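Methyl at the pyridine core and half-life at acidic pH

A few compounds are considered here, and "the series" means these few. Any claim that something is new, unique, unknown or untested is made for them only; others in the source may bear on it.

Measured compounds:
compound 1 `COc1cnc(C[S+]([O-])c2nc3cc(OC(F)F)ccc3[nH]2)cc1OC` with 2.1 h
compound 2 `COc1cnc(C[S+]([O-])c2nc3cc(OC(F)F)ccc3[nH]2)c(C)c1OC` with 3.7 h
compound 3 `COc1ccnc(C[S+]([O-])c2nc3cc(OC(F)(F)C(F)F)ccc3[nH]2)c1` with 0.8 h

All three were run in an ADME assay, at pH 5; on this read-out lower numbers stand for a shorter-lived compound and higher numbers for a longer-lived compound. Compound 3 is the shortest-lived of the three, with the nearest number being that of compound 1 and the furthest that of compound 2, both differences lying beyond the scatter. Compound 1 and compound 2 differ in one place: methyl in place of hydrogen on an aromatic carbon This change gave a 1.8-fold higher number from compound 1 to compound 2 (0.25 log units; within the scatter).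

Compound 4 `COc1ccnc(C[S+]([O-])c2nc3cc(OC(F)(F)C(F)F)ccc3[nH]2)c1C` has not yet been measured. It stands to compound 3 as compound 2 stands to compound 1: methyl in place of hydrogen on an aromatic carbon The same kind of change is made here, though the place is not identical in every detail; in compound 1 the carbon that receives the methyl is also meta to a methoxy group, while in compound 3 it is not. How the core of compound 3 differs from the core of compound 1 is not broken down here.

Beside the earlier step, the expectation for compound 4 in this assay is a step of a 1.8-fold higher number from compound 3 to compound 4 (0.24 log units; within the scatter), which rests on the step from compound 1 to compound 2 of a 1.8-fold higher number from compound 1 to compound 2 (0.25 log units; within the scatter). On that basis compound 4 is estimated to give 1.4 h, with a range from 0.7 h to 2.8 h.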

Compound 4, half-life: 0.3 h
For compound 4 the middle estimate is 4.7-fold (0.67 log units) above the measured one; measured number below the stated range.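

In this assay, putting a methyl group in place of hydrogen on the aromatic carbon of compound 3 gave a clear step, a 2.7-fold lower number from compound 3 to compound 4 (0.43 log units; beyond the scatter), which makes the 4-methoxy-3-methylpyridin-2-yl compound the shorter-lived of this pair. Set beside the earlier step, the result shows that the change did not behave alike on the two cores: the same change on two cores in this assay, a 1.8-fold higher number (0.25 log units; within the scatter) from compound 1 to compound 2 and a 2.7-fold lower number (0.43 log units; beyond the scatter) from compound 3 to compound 4, 4.7-fold (0.67 log units) apart, beyond the scatter of two such steps. So in this small series, a step measured for this change on one core is a poor guide to its step on the other, but with only one pair on each core, this shows neither why the two steps part nor how general the gap is.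

The compounds shown leave open which of the differences between the core of compound 1 and the core of compound 3 decides the outcome of the methyl change, as no pair here alters just one of those differences at a time. They also leave open whether an ethyl group or a chlorine atom on the same aromatic carbon would follow the methyl group on either core.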